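Iodine for bromine on the aryl thioether of compound 3

The source may hold more compounds than are shown below. What is called first, only, known or untested is meant among the compounds shown, and "the series" means these compounds.

Three measured compounds share one core and differ only in the group carried on the sulfur. Compound 1 `Cc1ccc(CSc2ncnc3c2ncn3[C@@H]2O[C@H](CO)[C@@H](O)[C@H]2O)cc1` bears a 4-methylbenzyl group there, and in an assay on isolated protein for binding affinity to Equilibrative nucleoside transporter 1 (Homo sapiens) (on this read-out higher numbers stand for weaker inhibition and lower numbers for stronger inhibition), compound 1 gives 457 nM. Compound 2 `OC[C@H]1O[C@@H](n2cnc3c(CSc4ccc(Cl)c(Cl)c4)ncnc32)[C@H](O)[C@@H]1O` bears a 3,4-dichlorophenyl group, and in this assay compound 2 gives 224 nM. Compound 3 `OC[C@H]1O[C@@H](n2cnc3c(CSc4cccc(Br)c4)ncnc32)[C@H](O)[C@@H]1O` bears a 3-bromophenyl group; in this assay compound 3 gives 363 nM, the second highest of the three numbers, with compound 1 nearest and compound 2 furthest.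

Both steps that lead to compound 3 stay inside the usual scatter: a 1.3-fold lower number from compound 1 to compound 3 (0.10 log units; within the scatter), and a 1.6-fold higher number from compound 2 to compound 3 (0.21 log units; within the scatter). Neither change of the aryl group moved the number beyond what repeated measurements would show.

Compound 4 `OC[C@H]1O[C@@H](n2cnc3c(CSc4cccc(I)c4)ncnc32)[C@H](O)[C@@H]1O` differs from compound 3 by iodo in place of bromo on an aromatic carbon, on an aromatic carbon of a six-membered aromatic ring of carbon only, meta to a large group. Among the measured compounds shown here, the closest precedent is the halogen change from compound 2 to compound 3, which stayed within the scatter, so no step beyond the scatter is expected here either. The expected step is a 1.1-fold lower number from compound 3 to compound 4 (0.05 log units; within the scatter), essentially flat. Compound 4 is therefore estimated to give about 320 nM in this assay, with a likely range from 150 nM to 700 nM.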

Compound 4, half-maximal inhibitory concentration: 245 nM
Compound 4: the middle estimate sits 1.3-fold (0.12 log units) above what was measured; measured number inside the range.
By their numbers in this assay, from the lowest: compounds 2, 4, 3 and 1 (each within the scatter of the next, the first and the last beyond it).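

In this assay, among the compounds shown here, iodo in place of bromo on this aromatic carbon gives a step that stays inside the scatter (a 1.5-fold lower number from compound 3 to compound 4 (0.17 log units; within the scatter)), and this is the first reading of one halogen exchanged for another with the rest of the aryl group left untouched. The 3-iodophenyl group also stays within the scatter of the 3,4-dichlorophenyl group (a 1.1-fold higher number from compound 2 to compound 4 (0.04 log units; within the scatter)) and of the group carried by compound 1 (a 1.9-fold lower number from compound 1 to compound 4 (0.27 log units; within the scatter)), although that last step comes close to the edge of the scatter, so this exchange adds a further aryl group to those that sit close together on this read-out. Nothing in the data at hand accounts for the size of these steps.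

The aryl groups shown carry only halogens or, in compound 1, a methyl, so the effect of a methoxy, an amine or a carboxylic acid on the same aromatic carbon remains open. Also open, going by these compounds, is whether 3-chlorophenyl or 3-fluorophenyl would continue the flat picture seen with bromo and iodo, or whether some other group here would produce a step beyond the scatter.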